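Branching the Chain Beside the Amide

The compounds below may be only part of what the source reports. "The series", "measured", "known", "first", "only" and "open" are said of these compounds alone.

Three simple amides and a related urea derivative have been tested in a functional assay on the whole organism (Spinal nerve) with Rattus norvegicus as the target, in the maximal electroshock model; a lower number here means that less compound is needed, a higher number that more compound is needed for the effect. Compound 1, with the structure `CCCC(C(N)=O)C(C)C`, gives 0.52 mg/kg. Compound 2, `CCC(C)C(CC)C(=O)NC(N)=O`, gives 0.49 mg/kg, and compound 3, `CC(C)(C)CC(=O)NC(N)=O`, gives 0.86 mg/kg. Compound 1 stands second highest of these three numbers, yet its gap to compound 2 and its wider gap to compound 3 both fall inside the usual scatter, so the three cannot be told apart with confidence.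

The unmeasured compound 4, `CC(C)C(C(N)=O)C(C)C`, holds the same atoms as compound 1 joined differently: isopropyl in place of propyl on a saturated chain carbon bound to a carbonyl carbon and a saturated chain carbon. For the measured compounds named here, the three measured compounds, differing widely in their chains and carbonyl-bearing groups, still land close together, and no step between them rises beyond the scatter.

For that reason the change from compound 1 to compound 4 is expected to bring no shift beyond the scatter, a step of a 1.0-fold lower number from compound 1 to compound 4 (0.02 log units; within the scatter). Compound 4 is therefore estimated at 0.5 mg/kg, with a range from 0.22 mg/kg to 1.2 mg/kg in this assay.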

Compound 4, dose for half-maximal effect: 0.88 mg/kg
Compound 4: the middle estimate sits 1.8-fold (0.25 log units) below what was measured, and the stated range covers the measured number.
By their numbers in this assay, from the lowest: compounds 2, 1, 3 and 4 (each within the scatter of the next).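

For the compounds shown here, this is the first direct step at this position: isopropyl in place of propyl on a saturated chain carbon bound to a carbonyl carbon and a saturated chain carbon gives a 1.7-fold higher number from compound 1 to compound 4 (0.23 log units; within the scatter) in this assay. For this one pair, then, rearranging the same three carbons produces no effect that can be separated from the ordinary variation between repeat measurements. Nothing available bears on why the step has this size.

From the compounds shown here alone, whether a longer chain such as butyl, a ring such as cyclopropyl or a hydroxyl group at this position would move the number beyond the scatter remains open. So does whether the same change would give a similar step in a urea derivative such as compound 2.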